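This account rests on a few compounds, and the source may have more. Where it says the series, first, only, none or still open, it means among the compounds named here.

Measured so far:
Compound 1, `C[C@@H](c1ccc(NC(=O)N2CC(c3cccnc3)C2)cc1)N1Cc2ccccc2C1=O`: in a functional assay on COR-L23 cells (Homo sapiens) for antiproliferative activity, read by CellTiter-Glo, with a stated time of 72 h (on this read-out lower numbers stand for stronger inhibition and higher numbers for weaker inhibition), compound 1 gives 8 nM.
Compound 2, `C[C@H](NC(=O)c1cccc(F)c1)c1ccc(NC(=O)N2CC(c3cccnc3)C2)cc1`: in this assay compound 2 gives 10 nM.
Compound 3, `C[C@@H](c1ccc(NC(=O)N2CC(c3cncc(N)c3)C2)cc1)N1Cc2ccccc2C1=O`: in this assay compound 3 gives 130 nM.

Compound 2 differs from compound 1 by one change: a group of 10 heavy atoms (7 carbon, 1 nitrogen, 1 oxygen, 1 fluorine; one six-membered aromatic ring of carbon only) in place of a group of 10 heavy atoms (8 carbon, 1 nitrogen, 1 oxygen; one five-membered non-aromatic ring with 1 hetero atom, one six-membered aromatic ring of carbon only), on a saturated chain carbon bound to an aromatic carbon and a saturated chain carbon. That change made a 1.3-fold higher number from compound 1 to compound 2 (0.10 log units; within the scatter). Compound 3 differs from compound 1 in its core by another change: amino in place of hydrogen on an aromatic carbon. This one made a 16-fold higher number from compound 1 to compound 3 (1.21 log units; beyond the scatter), the largest step seen among these three compounds.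

Compound 4, `C[C@H](NC(=O)c1cccc(F)c1)c1ccc(NC(=O)N2CC(c3cncc(N)c3)C2)cc1`, carries onto the core of compound 3 the same change already seen between compound 1 and compound 2: a group of 10 heavy atoms (7 carbon, 1 nitrogen, 1 oxygen, 1 fluorine; one six-membered aromatic ring of carbon only) in place of a group of 10 heavy atoms (8 carbon, 1 nitrogen, 1 oxygen; one five-membered non-aromatic ring with 1 hetero atom, one six-membered aromatic ring of carbon only), on a saturated chain carbon bound to an aromatic carbon and a saturated chain carbon. The place of the change is described in the same words in both pairs, so this is the same change made on a different core. The earlier instance gave a 1.3-fold higher number from compound 1 to compound 2 (0.10 log units; within the scatter). Resting on that single earlier instance, a step of similar size is expected here, a 1.2-fold higher number from compound 3 to compound 4 (0.09 log units; within the scatter). Compound 4 is therefore estimated at 160 nM, with a likely range from 70 nM to 370 nM.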

Compound 4, half-maximal inhibitory concentration: 630 nM
The estimate for compound 4 lay 3.9-fold (0.60 log units) below the measured number, and the stated range ends below it.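

In this assay, the same swap of side group, which gave a step within the scatter on the core of compound 1, gave a 4.8-fold higher number from compound 3 to compound 4 (0.69 log units; beyond the scatter), so the two instances do not match: the same change on two cores in this assay, a 1.3-fold higher number (0.10 log units; within the scatter) from compound 1 to compound 2 and a 4.8-fold higher number (0.69 log units; beyond the scatter) from compound 3 to compound 4, 3.9-fold (0.59 log units) apart, beyond the scatter of two such steps

Seen from the other side, amino in place of hydrogen on an aromatic carbon gave a 63-fold higher number from compound 2 to compound 4 (1.80 log units; beyond the scatter), again unlike its first instance: the same change on two cores in this assay, a 16-fold higher number (1.21 log units; beyond the scatter) from compound 1 to compound 3 and a 63-fold higher number (1.80 log units; beyond the scatter) from compound 2 to compound 4, 3.9-fold (0.59 log units) apart, beyond the scatter of two such steps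

Both changes raised the number each time, but the size of neither carried over unchanged from one core to the other; these four compounds form a single comparison and do not show why the sizes differ or how general this is.

As far as these compounds go, it remains open whether a methyl or a hydroxyl in place of the amino would also alter the step from the swap of side group.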